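The source may hold more compounds than are shown below. What is called first, only, known or untested is meant among the compounds shown, and "the series" means these compounds.

In an ADME assay on the whole organism (strain CD) for metabolic stability, with Rattus norvegicus as the target, at a dose of 1 mg/kg by the intravenous route (a higher number here means that the compound lasts longer, a lower number that the compound disappears faster), compound 2 `CN[C@H](C)C(=O)NCc1cccc(Cn2nc(NS(=O)(=O)c3ccc(Cl)s3)c3c(OC)cccc32)c1` gives 0.8 h. Within the data shown here, the only other measured compound, compound 1 `CC(=O)NCc1cccc(Cn2nc(NS(=O)(=O)c3ccc(Cl)s3)c3c(O)cccc32)c1`, gives 1.2 h in this assay, and the two numbers lie within the usual scatter of each other, so neither stands apart. Compound 3 `COc1cccc2c1c(NS(=O)(=O)c1ccc(Cl)s1)nn2Cc1cccc(CNC(=O)C(C)(C)N)c1` differs from compound 2 by a single rearrangement: 1-amino-1-methylethyl in place of 1-(methylamino)ethyl on a carbonyl carbon. Among the measured compounds shown here, no measured pair shows what such a change does to the half-life, so the step is estimated as no change at the digits printed from compound 2 to compound 3 (within the scatter), nothing beyond the scatter in either direction. Compound 3 is therefore expected to give about 0.8 h, somewhere between 0.4 h and 1.6 h.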

Compound 3, half-life: 1.3 h
For compound 3 the middle estimate is 1.6-fold (0.21 log units) below the measured one; low and high end bracket the measured number.
By their numbers in this assay, from the lowest: compounds 2, 1 and 3 (each within the scatter of the next).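

In this assay the exchange of 1-(methylamino)ethyl for 1-amino-1-methylethyl on a carbonyl carbon reads as a 1.6-fold higher number from compound 2 to compound 3 (0.21 log units; within the scatter). At this position, therefore, two groups with the same atoms, joined differently, are not told apart by the half-life, and the defined stereocentre of the leaving group can go without a step beyond the scatter. No evidence on hand bears on this result. From the compounds shown here alone, what a carboxylic acid or a longer carbon chain on this carbonyl carbon would give in this assay remains open.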